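Acetyl in Place of Dimethylamino: What to Expect

The compounds below may be only part of what the source reports. "The series", "measured", "known", "first", "only" and "open" are said of these compounds alone.

Measured so far:
compound 1, `CCOC(=O)c1cc(-c2ccc(OCC)cc2)ccn1`: 72%
compound 2, `CCOC(=O)c1cccc(-c2ccc(N(C)C)cc2)c1`: 87%
compound 3, `CCOC(=O)c1cccc(-c2ccc(CN3CCN(C)CC3)o2)c1`: 67%

All three were tested in an assay on COS-7 cells for inhibition of patatin-like phospholipase domain-containing protein 2 (Mus musculus), tested at 200 uM; on this read-out lower numbers stand for less inhibition and higher numbers for more inhibition at the one concentration tested (going by the name of the read-out). Compound 2 stands highest of the three numbers. Compound 1 comes nearest to it, with a lower number, a gap beyond the usual scatter; compound 3 is furthest, with a lower number still, also beyond the scatter. No pair of these compounds differs in only one place, so no single measured step shows how one change alone shifts this assay.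

The next compound, compound 4, `CCOC(=O)c1cccc(-c2ccc(C(C)=O)cc2)c1`, differs from compound 2 in one place: acetyl in place of dimethylamino on an aromatic carbon. Going by the values given here, with no measured step of one change to lean on, the expectation rests on where compound 2 stands and on the size of this change. The step from compound 2 to compound 4 in this assay is estimated as a number 17 percentage points lower from compound 2 to compound 4 (beyond the scatter), a moderate drop in inhibition, though a value within the scatter of compound 2 cannot be ruled out. Compound 4 is expected to give 70% in this assay, in a range from 45% to 90%.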

Compound 4, a percentage reported as inhibition, at one concentration (the size of the read-out at that concentration, not a potency): 36%
Compound 4: middle estimate off by 34 percentage points, on the high side; measured number outside the range, below it.
By their numbers in this assay, from the lowest: compound 4; then compounds 3 and 1 (each within the scatter of the next); then compound 2.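

In this assay, going by these compounds alone, the group on this aromatic carbon, para to a large group, turns out to matter a great deal: acetyl in place of dimethylamino gives a number 51 percentage points lower from compound 2 to compound 4 (beyond the scatter) and is the first single change that can be read on its own. Both groups have the same counts of heavy atoms, hydrogen-bond donors and hydrogen-bond acceptors, and neither has a ring or a net charge, so these counts do not account for the gap between the two compounds. What lies behind so large a step cannot be said, as no measurement here bears on it.

The compounds shown leave open where a methoxy group, a plain amino group or a carboxylic acid at this place would fall relative to compound 2 and compound 4. From the compounds shown here alone, whether the same exchange would give a similar step on the core of compound 1 also remains open.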